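This account rests on a few compounds, and the source may have more. Where it says the series, first, only, none or still open, it means among the compounds named here.

Measured compounds in the series:

compound 1 `O=C(COc1cccc2ccccc12)N/N=C/c1c(O)ccc2ccccc12` — 4 ug/mL
compound 2 `O=C(COc1cccc2ccccc12)N/N=C/c1ccc(O)cc1` — 20 ug/mL
compound 3 `COc1ccc(/C=N/NC(=O)COc2cccc3ccccc23)cc1OC` — >= 20 ug/mL

In an ADME assay on HEL cells (Homo sapiens) for cytotoxicity (a lower number here means that less compound is tolerated, a higher number that more compound is tolerated), compound 2 gives 20 ug/mL, the highest of the two numbers read. The nearest number is that of compound 1, which gives 4 ug/mL, and the gap between these two values lies beyond the usual scatter. For compound 3 the value >= 20 ug/mL is a limit of the assay, not a number. Noted on the measured values is the limit of >= 20 ug/mL in this assay, at which 1 of the 3 values shown sits.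

Compound 4 `Cc1ccc(/C=N/NC(=O)COc2cccc3ccccc23)cc1` has not yet been measured in this assay. Against compound 2 the change is methyl in place of hydroxy on an aromatic carbon. Within the data shown here, no step between measured compounds carries this change, and no measured evidence bears on how it would move the read-out; compound 3 and compound 2 only show that values around the upper end of the range are reached in this set. The expectation for compound 4 in this assay is therefore a step from compound 2 of about no change at the digits printed from compound 2 to compound 4 (within the scatter), none beyond the scatter. The estimated value for compound 4 is 20 ug/mL, with a range from 8 ug/mL to 40 ug/mL, and a real chance that only a limit is reported.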

Compound 4, minimum cytotoxic concentration: 20 ug/mL
Compound 4: middle estimate and measured number agree at the digits printed; measured number inside the range.
By their numbers in this assay, from the lowest: compound 1; then compounds 2 and 4 (each within the scatter of the next).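

In this assay, the first step read at this position, on an aromatic carbon para to a large group, gives no change at the digits printed from compound 2 to compound 4 (within the scatter), with methyl in place of hydroxy. For this pair, the read-out therefore holds when the hydrogen-bond donor and hydrogen-bond acceptor counted on hydroxy are absent from the entering group. Compound 3 carries a limit and not a number, so any room above the reading shared by this pair stays unseen: the limit of >= 20 ug/mL in this assay, at which 1 of the 4 values shown sits.

Going by these compounds, whether an amine, a carboxylic acid or a longer chain at this position would leave the number in this assay where it stands remains open, as one step on one pair says nothing about groups of other kinds. Among these compounds, compound 1 gives 4 ug/mL, but it differs from compound 2 and compound 4 in more than one place, so no step to it can be read and what sets its number remains unresolved.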